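Chloro on the Benzyl Arm of a Cyclic Sulfonylurea

The source may hold more compounds than are shown below. What is called first, only, known or untested is meant among the compounds shown, and "the series" means these compounds.

Compound 1 `O=C1c2ccccc2N(Cc2ccccc2)S(=O)(=O)N1Cc1ccccc1` is the starting point. In a functional assay on CCRF-CEM cells (Homo sapiens) for inhibition (a higher number here means that more compound is tolerated, a lower number that less compound is tolerated), compound 1 gives 108000 nM. Among the compounds with values here, the only companion with a number so far is compound 2 `O=C1c2ccccc2N(Cc2ccccc2)S(=O)(=O)N1COCc1ccccc1`, which carries a benzyloxy group in place of phenyl on a saturated chain carbon bound to an amide-type nitrogen in the ring; in this assay compound 2 gives 100000 nM. The step of a 1.1-fold lower number from compound 1 to compound 2 (0.03 log units; within the scatter) lies within the scatter, so the two compounds sit together and neither can be called more or less tolerated than the other.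

Compound 3 `O=C1c2ccccc2N(Cc2cccc(Cl)c2)S(=O)(=O)N1Cc1ccccc1` is not yet measured. It differs from compound 1 by chloro in place of hydrogen on an aromatic carbon. Within the data shown here, no measured step touches this benzyl arm, so nothing seen so far speaks directly to a chloro on that ring. Among the measured compounds shown here, the one step on record, from compound 1 to compound 2, changed a different arm and moved nothing beyond the scatter. For compound 3 the expected step is therefore a 1.1-fold lower number from compound 1 to compound 3 (0.03 log units; within the scatter), none beyond the scatter. Compound 3 is estimated at 100000 nM, with a range from 40000 nM to 250000 nM.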

Compound 3, half-maximal cytotoxic concentration: 2100000 nM
For compound 3 the middle estimate is 21-fold (1.32 log units) below the measured one, and the stated range ends below it.
By their numbers in this assay, from the lowest: compounds 2 and 1 (each within the scatter of the next); then compound 3.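

Putting a single chlorine atom in place of a hydrogen, which turns benzyl into 3-chlorobenzyl, gives a 19-fold higher number from compound 1 to compound 3 (1.29 log units; beyond the scatter) in this assay, so much more of the compound is tolerated after this one small edit. The earlier pair showed no such sensitivity: the change on the other arm gave a 1.1-fold lower number from compound 1 to compound 2 (0.03 log units; within the scatter) and left the two compounds together, whereas this aromatic carbon on the benzyl arm is a place where a one-atom change moves the number far beyond the scatter. Nothing measured on these compounds accounts for the size of this step, so it stands as an observation without an explanation.

As far as these compounds go, only hydrogen and chloro have been compared at this carbon, so it remains open whether the large step is particular to chloro or would also appear with a fluoro, a methoxy, an amine or a carboxylic acid in the same place. From the compounds shown here alone, it is also open whether a chloro on the ring of the other arm, the benzyl group of compound 1 that stays unchanged here, would move the number in the same way.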